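Swapping a Triazole for a Pyrimidine on Two Cores

A few compounds are considered here, and "the series" means these few. Any claim that something is new, unique, unknown or untested is made for them only; others in the source may bear on it.

Compound 1 `CCN(C(=O)c1cc(C)ccc1-n1nccn1)[C@@H](C)Cn1nnc(-c2ccc(F)cc2)n1` is an amide whose core carries a small five-membered ring. In a functional assay on cells for antagonist activity at Orexin receptor type 2 (Homo sapiens), read by fluorescence and calcium flux, with a stated time of 30 min (a higher number here means a weaker inhibitor, a lower number a stronger inhibitor), compound 1 gives 2.57 nM. Compound 2 `CCN(C(=O)c1cc(C)ccc1-c1ncccn1)[C@@H](C)Cn1nnc(-c2ccc(F)cc2)n1` keeps everything else and carries a six-membered ring in that spot; the difference is pyrimidin-2-yl in place of 2H-1,2,3-triazol-2-yl on an aromatic carbon. In this assay compound 2 gives 36 nM, and the step of a 14-fold higher number from compound 1 to compound 2 (1.15 log units; beyond the scatter) shows how much weaker the inhibition became after this swap.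

Compound 3 `CCN(C(=O)c1nc(C)ccc1-n1nccn1)[C@@H](C)Cn1nnc(-c2ccc(F)cc2)n1` has a core that is not the core of compound 1; the difference between the two cores is not broken down here. In this assay compound 3 gives 119 nM, the highest number of the three measured compounds.

Compound 4 `CCN(C(=O)c1nc(C)ccc1-c1ncccn1)[C@@H](C)Cn1nnc(-c2ccc(F)cc2)n1` stands to compound 3 as compound 2 stands to compound 1: pyrimidin-2-yl in place of 2H-1,2,3-triazol-2-yl on an aromatic carbon. This is the same kind of change, not the same change. In compound 1 the group sits on an aromatic carbon of a six-membered aromatic ring of carbon only, whereas in compound 3 it sits on a six-membered aromatic ring with 1 nitrogen, two atoms from the ring nitrogen. If the swap acts as before, compound 4 is expected to show a step of about a 13-fold higher number from compound 3 to compound 4 (1.10 log units; beyond the scatter), which rests on the earlier step of a 14-fold higher number from compound 1 to compound 2 (1.15 log units; beyond the scatter). The estimate for compound 4 in this assay is 1500 nM, within a range from 500 nM to 5000 nM.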

Compound 4, half-maximal inhibitory concentration: 1310 nM
Compound 4: the middle estimate sits 1.1-fold (0.06 log units) above what was measured, within the range that was stated.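

On the core of compound 3, putting pyrimidin-2-yl in place of 2H-1,2,3-triazol-2-yl again weakens inhibition in this assay, with an 11-fold higher number from compound 3 to compound 4 (1.04 log units; beyond the scatter). Set beside the earlier step, the size of the change holds from one core to the other: the same change on two cores in this assay, a 14-fold higher number (1.15 log units; beyond the scatter) from compound 1 to compound 2 and an 11-fold higher number (1.04 log units; beyond the scatter) from compound 3 to compound 4, 1.3-fold (0.10 log units) apart, within the scatter of two such steps. So, for these two pairs, the swap costs about the same on either core, and the step seen on the first core was a fair guide to the step on the second; this is still only two pairs on two cores, which does not make a rule for the whole series and does not explain why the pyrimidine compounds are the weaker inhibitors.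

The compounds shown leave open whether a similar step would appear with a different group in that place, such as an amine or a methoxy group, or with a longer chain in place of the ethyl group on the amide. All four numbers also come from this assay, and how the swap behaves in any other kind of measurement remains an open question.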